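Changing the Fluorinated Tail: From Compound 3 to Compound 4

The source may hold more compounds than are shown below. What is called first, only, known or untested is meant among the compounds shown, and "the series" means these compounds.

Measured in a functional assay on SGC-7901 cells (Homo sapiens) for cytotoxicity, read by MTT assay, with a stated time of 48 h; on this read-out higher numbers stand for weaker inhibition and lower numbers for stronger inhibition:
Compound 1, `CCN(CC)c1ccc2cc(C(=O)c3ccc(N4CCN(C(=O)CN5CCN(C(=O)CCl)CC5)CC4)cc3)oc2c1`: 1630 nM
Compound 2, `CCN(CC)c1ccc2cc(C(=O)c3ccc(N4CCN(C(=O)CN5CCN(C(=O)/C=C/c6ccccc6)CC5)CC4)cc3)oc2c1`: 1140 nM
Compound 3, `CCN(CC)c1ccc2cc(C(=O)c3ccc(N4CCN(C(=O)CN5CCN(Cc6ccc(F)c(F)c6)CC5)CC4)cc3)oc2c1`: 1780 nM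

Compound 3 carries the highest of the three numbers, yet its steps to the others, a 1.1-fold higher number from compound 1 to compound 3 (0.04 log units; within the scatter) and a 1.6-fold higher number from compound 2 to compound 3 (0.19 log units; within the scatter), both lie within the scatter, as does a 1.4-fold lower number from compound 1 to compound 2 (0.16 log units; within the scatter). Compound 4, `CCN(CC)c1ccc2cc(C(=O)c3ccc(N4CCN(C(=O)CN5CCN(Cc6ccc(C(F)(F)F)cc6)CC5)CC4)cc3)oc2c1`, differs from compound 3 by 4-(trifluoromethyl)phenyl in place of 3,4-difluorophenyl on a saturated chain carbon bound to an amine nitrogen in a ring. Within the data shown here, no measured step alters this same group, but the two steps ending at compound 3 show that exchanging the group on that ring nitrogen left this assay unchanged beyond the scatter. The expectation is therefore a 1.0-fold lower number from compound 3 to compound 4 (0.02 log units; within the scatter), no step beyond the scatter. Compound 4 is estimated at 1700 nM, between 800 nM and 3600 nM.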

Compound 4, half-maximal inhibitory concentration: 32000 nM
Estimate against measurement, compound 4: 19-fold (1.27 log units) below, outside the stated range (above it).
By their numbers in this assay, from the lowest: compounds 2, 1 and 3 (each within the scatter of the next); then compound 4.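

In this assay the aromatic group on a saturated chain carbon bound to an amine nitrogen in a ring proves decisive: 4-(trifluoromethyl)phenyl in place of 3,4-difluorophenyl gives an 18-fold higher number from compound 3 to compound 4 (1.25 log units; beyond the scatter) even though the earlier exchanges there stayed within the scatter. Compound 4 also stands apart through a 28-fold higher number from compound 2 to compound 4 (1.45 log units; beyond the scatter) and through a 20-fold higher number from compound 1 to compound 4 (1.29 log units; beyond the scatter) so this ring nitrogen does not accept every group equally. Nothing available explains this jump.

From the compounds shown here alone, whether the trifluoromethyl group itself or its ring position matters remains open. A plain benzyl or 4-chlorobenzyl group on the same nitrogen could help separate these.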